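Trifluoromethyl in Place of Hydrogen on Compound 1

This account rests on a few compounds, and the source may have more. Where it says the series, first, only, none or still open, it means among the compounds named here.

Compound 1: `CC1(C)C=C(n2ccccc2=O)c2ccccc2O1` — 5.05
Compound 2: `CC1(C)C=C(n2ccccc2=O)c2cc(C(=O)c3ccccc3F)ccc2O1` — 6.34
Compound 3: `Cc1ccccc1C(=O)c1ccc2c(c1)C(n1ccccc1=O)=CC(C)(C)O2` — 6.25

Of the compounds shown here, three have been measured in a functional assay (trachea) with Rattus norvegicus as the target; a higher number here means a more potent compound, by a factor of ten per unit of this negative logarithm, a lower number a less potent compound. Compound 1 stands lowest of the three: compound 3 is nearest, with a number 1.20 log units higher from compound 1 to compound 3 (beyond the scatter), and compound 2 furthest, with a number 1.29 log units higher from compound 1 to compound 2 (beyond the scatter). Between the two larger compounds the difference is small, a number 0.09 log units lower from compound 2 to compound 3 (within the scatter).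

Compound 4, `CC1(C)C=C(n2ccccc2=O)c2cc(C(F)(F)F)ccc2O1`, has not been measured. It differs from compound 1 in one place: trifluoromethyl in place of hydrogen on an aromatic carbon. The two steps that bear on this change both start from compound 1 and both are large: (2-fluorophenyl)carbonyl or (2-methylphenyl)carbonyl entering in place of hydrogen on an aromatic carbon. Trifluoromethyl enters on an aromatic carbon as well, but it is a far smaller group without a carbonyl, so the measured steps give only an indirect guide. A rise is expected, though a smaller one; the expected step is a number 0.55 log units higher from compound 1 to compound 4 (beyond the scatter). Compound 4 is therefore estimated at 5.6, with a range from 5 to 6.3.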

Compound 4, logarithm of the reciprocal of the active concentration, log(1/C): 7.37
Beside the measured number, compound 4's estimate is 1.77 log units below it; measured number above the stated range.
By their numbers in this assay, from the lowest: compound 1; then compounds 3 and 2 (each within the scatter of the next); then compound 4.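

Trifluoromethyl in place of hydrogen gives a number 2.32 log units higher from compound 1 to compound 4 (beyond the scatter), so a gain at this aromatic carbon does not need a carbonyl or a second aromatic ring in the entering group. The two larger groups are also surpassed at the same carbon: replacing (2-methylphenyl)carbonyl with trifluoromethyl gives a number 1.12 log units higher from compound 3 to compound 4 (beyond the scatter), and replacing (2-fluorophenyl)carbonyl with it gives a number 1.03 log units higher from compound 2 to compound 4 (beyond the scatter). No measurement offered here explains why the smaller group outdoes both larger ones.

On these data alone, with only these compounds, it remains open whether other small groups at this carbon, such as a nitrile, a methyl or a chlorine atom, would give a similar rise or whether it is particular to trifluoromethyl. As far as these compounds go, it is also open how trifluoromethyl would fare on a different carbon of the same aromatic ring.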